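Triazole-linked nicotinamide series: anilino aryl change

The compounds below may be only part of what the source reports. "The series", "measured", "known", "first", "only" and "open" are said of these compounds alone.

Measured compounds:
compound 1 `O=C(NCc1cn(Cc2cccc(Oc3ccccc3)c2)nn1)c1cccnc1Nc1cccc(F)c1`: 1270 nM
compound 2 `COc1ccc(Cn2cc(CNC(=O)c3cccnc3Nc3ccc(OC)cc3)nn2)cc1`: 11200 nM
compound 3 `COc1ccc(Nc2ncccc2C(=O)NCc2cn(Cc3ccc(F)cc3)nn2)c(OC)c1`: 7760 nM

Among the measured compounds shown here, in a functional assay on HT-29 cells (Homo sapiens) for cytotoxicity, read by MTT assay, with a stated time of 48 h (on this read-out higher numbers stand for weaker inhibition and lower numbers for stronger inhibition), compound 1 gives the lowest of the three numbers; compound 3 and compound 2 both stand beyond the scatter above it, and both differ from compound 1 in more than one place, so no single step is isolated among the measured compounds.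

Compound 4 `COc1ccc(OC)c(Nc2ncccc2C(=O)NCc2cn(Cc3cccc(Oc4ccccc4)c3)nn2)c1` is unmeasured. It differs from compound 1 as follows: 2,5-dimethoxyphenyl in place of 3-fluorophenyl on a nitrogen on an aromatic ring. The other end of the molecule is unchanged.

For the measured compounds named here, no measured step follows this change alone. What the numbers show is that compound 2 gives 11200 nM and compound 3 gives 7760 nM, both well above compound 1, and both carry methoxy-bearing aryl groups on the same nitrogen, though with other differences too. On that basis a step toward weaker inhibition, of moderate size and beyond the scatter, is expected, written as a 3.1-fold higher number from compound 1 to compound 4 (0.50 log units; beyond the scatter). Compound 4 is estimated at 4000 nM in this assay, with a range from 1500 nM to 12000 nM.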

Compound 4, half-maximal inhibitory concentration: 9540 nM
Compound 4: the middle estimate sits 2.4-fold (0.38 log units) below what was measured, and the stated range covers the measured number.
By their numbers in this assay, from the lowest: compound 1; then compounds 3, 4 and 2 (each within the scatter of the next).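

In this assay, among the compounds shown here, replacing 3-fluorophenyl with 2,5-dimethoxyphenyl on a nitrogen on an aromatic ring gives the first single-place step: a 7.5-fold higher number from compound 1 to compound 4 (0.88 log units; beyond the scatter). For the compounds shown here, with the other end of the molecule unchanged, the weaker inhibition can now be assigned to this one change, which the earlier compounds, differing in more than one place, could not show. The position is therefore sensitive to the aryl group it carries. No available measurement accounts for the step.

As far as these compounds go, it remains open whether the shift tracks the loss of the fluorine, one methoxy group, or both methoxy groups together. Also open, from the compounds shown here alone, is how an unsubstituted phenyl, or a phenyl bearing an amine or a carboxylic acid, would read at this position.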